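Capping the Acid of Compound 3 with Morpholine

The source may report more compounds than this note shows. Statements on the series, on what has been measured and on what is new or still open speak of the compounds shown alone.

Compound 3 `N=C(N)c1ccc(CNC(=O)[C@@H]2CCCN2C(=O)[C@@H](CC(=O)O)NS(=O)(=O)Cc2ccccc2)cc1` gives the highest number of the three measured compounds in an assay on isolated protein for inhibition of transmembrane protease serine 11D (Homo sapiens), read by fluorescence (on this read-out higher numbers stand for weaker inhibition and lower numbers for stronger inhibition), namely 1430 nM, whereas compound 1 `N=C(N)NCCCC[C@@H](NS(=O)(=O)Cc1ccccc1)C(=O)N1CCC[C@H]1C(=O)NCc1ccc(C(=N)N)cc1` gives 13 nM and compound 2 `CC(C)[C@@H](NS(=O)(=O)Cc1ccccc1)C(=O)N1CCC[C@H]1C(=O)NCc1ccc(C(=N)N)cc1` gives 76 nM. Compound 4 `N=C(N)c1ccc(CNC(=O)[C@@H]2CCCN2C(=O)[C@@H](CC(=O)N2CCOCC2)NS(=O)(=O)Cc2ccccc2)cc1` differs from compound 3 by morpholin-4-yl in place of hydroxy on a carbonyl carbon. Among the compounds with values here, no measured step alters this carbonyl carbon's neighbour; the steps that bear on the side chain are a 110-fold higher number from compound 1 to compound 3 (2.04 log units; beyond the scatter) and a 19-fold higher number from compound 2 to compound 3 (1.27 log units; beyond the scatter), which together mark the carboxymethyl chain as the weakest of the three tried. With the carboxy hydroxy gone, a modest step toward stronger inhibition is expected, a 2.9-fold lower number from compound 3 to compound 4 (0.46 log units; beyond the scatter) in this assay. Compound 4 is therefore estimated at 500 nM, with a likely range of 150 nM to 2000 nM.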

Compound 4, inhibition constant: 183 nM
The estimate for compound 4 lay 2.7-fold (0.44 log units) above the measured number; low and high end bracket the measured number.
By their numbers in this assay, from the lowest: compound 1; then compound 2; then compound 4; then compound 3.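

In this assay, morpholin-4-yl in place of hydroxy on the carbonyl carbon gives a 7.8-fold lower number from compound 3 to compound 4 (0.89 log units; beyond the scatter), so the carboxymethyl chain's poor standing does not carry over to its capped form. The ((morpholin-4-yl)carbonyl)methyl chain still trails isopropyl, with a 2.4-fold higher number from compound 2 to compound 4 (0.38 log units; beyond the scatter), and trails the chain of compound 1 further, with a 14-fold higher number from compound 1 to compound 4 (1.15 log units; beyond the scatter). No evidence is available to explain these steps. Going by these compounds, whether a primary amide, a piperidin-1-yl amide or a longer chain ending in the same carbonyl would narrow the remaining gap to compound 1 stays open.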